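Replacing pyridin-3-yl with thiophen-2-yl in compound 3

This account rests on a few compounds, and the source may have more. Where it says the series, first, only, none or still open, it means among the compounds named here.

In a functional assay on MES-SA/Dx5 cells (Homo sapiens) for inhibition, with a stated time of 72 h (on this read-out higher numbers stand for weaker inhibition and lower numbers for stronger inhibition), compound 1 (`Oc1c(CN2CCCCC2)ccc2cccnc12`) gives 850 nM; 832 nM (2 entries). Compound 2 (`Oc1c(C(c2cccnc2)N2CCCC2)ccc2cccnc12`) gives 23400 nM, and compound 3 (`Oc1c(C(c2cccnc2)N2CCCCC2)ccc2cccnc12`) gives 8510 nM, the lower of these two single values, although the entries for compound 1 lie lower still. Compound 4 (`Oc1c(C(c2cccs2)N2CCCCC2)ccc2cccnc12`) departs from compound 3 as follows: thiophen-2-yl in place of pyridin-3-yl on a saturated chain carbon bound to an amine nitrogen in a ring and an aromatic carbon. Among the measured compounds shown here, no measured step changes the group at this place. For the measured compounds named here, the one available step, a 2.7-fold lower number from compound 2 to compound 3 (0.44 log units; beyond the scatter), changes the amine ring instead and serves only as a guide to size. Compound 1, which lacks this aromatic group, has the lower value of 850 nM; 832 nM (2 entries), so the direction remains tentative. The expected change is a 2.1-fold lower number from compound 3 to compound 4 (0.33 log units; beyond the scatter), a modest move towards a lower number. Compound 4 is estimated at 4000 nM, with an expected range of 1300 nM to 12000 nM.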

Compound 4, half-maximal inhibitory concentration: 11500 nM
Beside the measured number, compound 4's estimate is 2.9-fold (0.46 log units) below it; the range from low to high includes it.
By their numbers in this assay, from the lowest: compounds 3 and 4 (each within the scatter of the next); then compound 2.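

This first change of the aromatic group on the saturated chain carbon bound to an amine nitrogen in a ring and an aromatic carbon gives a 1.4-fold higher number from compound 3 to compound 4 (0.13 log units; within the scatter) in this assay. Compounds 3 and 4 therefore read alike, with thiophen-2-yl and pyridin-3-yl giving equivalent results at this place. Nothing available here accounts for this equivalence.

Compound 1 gives 850 nM; 832 nM (2 entries) without an aromatic group at this place. The compounds shown leave open how a phenyl or a 4-methoxyphenyl group would read here.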